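This account rests on a few compounds, and the source may have more. Where it says the series, first, only, none or still open, it means among the compounds named here.

Measured compounds:

Compound 1 `CCCCCCCCCCCCCCCCC/C=C1/CC(CO)(COC(C)=O)OC1=O` — 7.11
Compound 2 `O=C1CCCCCCCCCCCCCC/C=C2/CC(CO)(CO1)OC2=O` — 3.85
Compound 3 `O=C1CCCCCCCCCCCCCCCCCC/C=C2/CC(CO)(CO1)OC2=O` — 5.81

In a physicochemical assay for lipophilicity (a lower number here means a more polar compound, a higher number a more lipophilic compound), compound 3 stands second highest of the three numbers. Compound 1 sits a step higher than compound 3, a gap beyond the usual scatter, while compound 2 lies well lower, a gap that is also beyond the scatter.

Compound 4 `O=C1CCCCCCCCCCCCCCCCCC/C=C2\CC(CO)(CO1)OC2=O` differs from compound 3 only in one respect: the two compounds have the same atoms and bonds; at least one stereo element is drawn with a configuration in one of them and without one in the other: 1 of 2 stereo elements differ; a double bond is drawn Z in compound 3 and E in compound 4. Nothing leaves and nothing enters; the two compounds carry the same atoms and bonds.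

For the measured compounds named here, because no pair of measured compounds separated by a single change has been measured here, the size of this step cannot be read from the data. For a change that alters only the geometry of one double bond, a step within the scatter is expected, with no clear direction. Compound 4 is therefore expected to give about 5.8 in this assay, between 5.4 and 6.2, which corresponds to an expected step of a number 0.01 log units lower from compound 3 to compound 4 (within the scatter).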

Compound 4, partition coefficient: 5.81
Compound 4: middle estimate off by 0.01 log units, on the low side; the range from low to high includes it.
By their numbers in this assay, from the lowest: compound 2; then compounds 3 and 4 (each within the scatter of the next); then compound 1.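

In this assay, redrawing the double bond from Z to E gives no change at the digits printed from compound 3 to compound 4 (within the scatter), the first step across a single change among these compounds. With all atoms and bonds held the same, the read-out shows no response to the drawn geometry at this double bond. One point limits how far this comparison can be taken: the fact that one of compounds 3 and 4 is drawn with a defined configuration and the other without, at the place where they differ

The compounds shown leave open whether the other stereo element behaves the same way. They also leave open whether the double bond geometry would still leave the read-out unmoved in a compound carrying an amine or a carboxylic acid on the shared core.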